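Butyl for 4-chlorophenyl on the spiro-fused ring of compound 1

The source may report more compounds than this note shows. Statements on the series, on what has been measured and on what is new or still open speak of the compounds shown alone.

Compound 1, with the structure `O=C1NC2(CC2c2ccc3cccc(OCc4ccccc4)c3n2)C(=O)N1c1ccc(Cl)cc1`, gives 300 mg/kg in a functional assay on the whole organism (strain Kunming) with Mus musculus as the target, in the maximal electroshock model, with a stated time of 0.5 h; on this read-out higher numbers stand for an effect only at larger amounts of compound and lower numbers for an effect already at smaller amounts. It stands level with compound 2, `CC(C)N1C(=O)NC2(CC2c2ccc3cccc(OCc4ccccc4)c3n2)C1=O`, which gives 300 mg/kg, and with compound 3, `O=C1NC2(CC2c2ccc3cccc(OCc4ccccc4)c3n2)C(=O)N1c1ccc(F)cc1`, which gives 300 mg/kg; the steps of no change at the digits printed from compound 1 to compound 2 (within the scatter) and no change at the digits printed from compound 1 to compound 3 (within the scatter) both lie within the scatter. Compound 4, `CCCCN1C(=O)NC2(CC2c2ccc3cccc(OCc4ccccc4)c3n2)C1=O`, differs from compound 1 in one place: butyl in place of 4-chlorophenyl on an amide-type nitrogen in a ring. Going by the values given here, the step that bears on this is the one from compound 1 to compound 2, where an alkyl group also replaced the 4-chlorophenyl group on the same nitrogen and gave no change at the digits printed from compound 1 to compound 2 (within the scatter). Compound 4 is therefore expected to show no step beyond the scatter, no change at the digits printed from compound 1 to compound 4 (within the scatter), and its estimated minimum effective dose is 300 mg/kg, with a range from 150 mg/kg to 600 mg/kg.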

Compound 4, minimum effective dose: 300 mg/kg
Estimate against measurement, compound 4: no gap at the digits printed, and the stated range covers the measured number.
By their numbers in this assay, from the lowest: compounds 1, 2, 3 and 4 (each within the scatter of the next).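

In this assay an unbranched chain on the amide-type nitrogen in a ring reads the same as the branched one (no change at the digits printed from compound 2 to compound 4 (within the scatter)) and the same as both aryl groups (no change at the digits printed from compound 1 to compound 4 (within the scatter); no change at the digits printed from compound 3 to compound 4 (within the scatter)). With butyl added, this read-out separates neither aryl from alkyl nor branched from unbranched at this position. Nothing available here explains this flat result.

The compounds shown leave open whether any group on this nitrogen can bring the dose down. A free amine or a carboxylic acid at the end of a longer chain, or the amide hydrogen alone, might read differently.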